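Thiazole attachment point and tolerated concentration in the bicyclic series

The compounds below may be only part of what the source reports. "The series", "measured", "known", "first", "only" and "open" are said of these compounds alone.

Compound 3 `C[C@H]1[C@H](NCc2cncs2)C[C@H]2C[C@@H]1C2(C)C` sits at the limit in an ADME assay on MDCK cells (Canis lupus familiaris) for cytotoxicity, read by microscopy, with a stated time of 48 h (a higher number here means that more compound is tolerated, a lower number that less compound is tolerated), where compound 3 gives > 100000 nM. Compound 1 `C[C@H]1[C@H](NCc2cncnc2)C[C@H]2C[C@@H]1C2(C)C` gives > 100000 nM in this assay, also a limit. Compound 2 `C[C@H]1[C@H](NCc2sccc2Br)C[C@H]2C[C@@H]1C2(C)C` gives 50000 nM in this assay. The measured moves onto compound 3 are an at least 2.0-fold higher number from compound 2 to compound 3 (0.30 log units; that floor lies within the scatter) and a step that the two limits leave unreadable from compound 1 to compound 3, the first only a floor and the second unreadable because of the limit of > 100000 nM in this assay, at which 2 of the 3 values shown sit. Compound 4 `C[C@H]1[C@H](NCc2nccs2)C[C@H]2C[C@@H]1C2(C)C` differs from compound 3 by 1,3-thiazol-2-yl in place of 1,3-thiazol-5-yl on a saturated chain carbon bound to an amine nitrogen. Within the data shown here, no measured step exchanges one attachment of the same ring for another, so no direction is expected; the change is expected to give a number no higher from compound 3 to compound 4 (the limit leaves the size open) in this assay, within the scatter, and compound 4 will likely again be reported only as a limit. Compound 4 is therefore estimated at 100000 nM, between 50000 nM and 200000 nM.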

Compound 4, minimum cytotoxic concentration: > 100000 nM
Compound 4 gave a limit, no number (the forecaster's own chance of this, stated with the estimate: 70%); the middle value sits exactly at the limit.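

Compound 4 gives > 100000 nM in this assay, which is a limit and not a number, so a second attachment of the thiazole ring also reaches the limit. The exchange of 3-bromothiophen-2-yl for 1,3-thiazol-2-yl gives an at least 2.0-fold higher number from compound 2 to compound 4 (0.30 log units; that floor lies within the scatter). The steps to compound 4 from compound 3 and from compound 1 cannot be read, because both ends of each step sit at the limit: the limit of > 100000 nM in this assay, at which 3 of the 4 values shown sit.

Going by these compounds, how far compound 3 and compound 4 actually lie from each other stays open. Also open, on these data alone, is whether a bromine on the 1,3-thiazol-2-yl ring, or a plain phenyl ring in its place, would bring the number off the limit.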